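The source may hold more compounds than are shown below. What is called first, only, known or untested is meant among the compounds shown, and "the series" means these compounds.

Measured in a functional assay on HCT-116 cells (Homo sapiens) for cytotoxicity, read by MTT assay, with a stated time of 72 h; a higher number here means a weaker inhibitor, a lower number a stronger inhibitor:
compound 1, `COc1ccc(C(=O)NC[C@H]2c3[nH]c4ccccc4c3C[C@H]3[C@H]4c5[nH]c6ccccc6c5C[C@@H]([C@H](C#N)N23)N4C)cc1`, gives 430 nM
compound 2, `CCc1ccc(C(=O)NC[C@H]2c3[nH]c4ccccc4c3C[C@H]3[C@H]4c5[nH]c6ccccc6c5C[C@@H]([C@H](C#N)N23)N4C)cc1`, gives 100 nM

Going by the values given here, compound 2 holds the lower of the two numbers, and the single measured step, a 4.3-fold lower number from compound 1 to compound 2 (0.63 log units; beyond the scatter), separates it from compound 1. Compound 3, `CN1[C@@H]2c3[nH]c4ccccc4c3C[C@H]1[C@H](C#N)N1[C@@H](CNC(=O)c3cccc4c3CCCC4)c3[nH]c4ccccc4c3C[C@@H]21`, differs from compound 2 by 1,2,3,4-tetrahydronaphthalen-5-yl in place of 4-ethylphenyl on a carbonyl carbon. That measured step swapped one group on the aromatic ring for another, whereas here the aromatic ring gains a fused non-aromatic ring, so it bears on the new change only loosely. A modest move is expected, a 1.5-fold higher number from compound 2 to compound 3 (0.18 log units; within the scatter). Compound 3 is therefore estimated at 150 nM in this assay, within 50 nM to 500 nM.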

Compound 3, half-maximal inhibitory concentration: 4210 nM
Estimate against measurement, compound 3: 28-fold (1.45 log units) below; the whole stated range lies below it.
By their numbers in this assay, from the lowest: compound 2; then compound 1; then compound 3.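

The carbonyl-bound aryl group proves far less forgiving than the first pair showed: in this assay, 1,2,3,4-tetrahydronaphthalen-5-yl in place of 4-ethylphenyl brings a 42-fold higher number from compound 2 to compound 3 (1.62 log units; beyond the scatter), a large step. The same group in place of 4-methoxyphenyl brings a 9.8-fold higher number from compound 1 to compound 3 (0.99 log units; beyond the scatter), so compound 3 lies on the high side of both earlier compounds. No measurement shown here accounts for this loss.

The compounds shown leave open whether the fused ring itself or its place of attachment carries the loss. They also leave open how an amine or a carboxylic acid on the aromatic ring would fare.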